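The source may report more compounds than this note shows. Statements on the series, on what has been measured and on what is new or still open speak of the compounds shown alone.

Compound 1 `C=C(Br)C(=O)Nc1cccc(-c2cn3nc(Cc4cccc(OC)c4)sc3n2)c1` is the reference point of this small set. In a functional assay on FM3A cells (Mus musculus) for inhibition, read by cell counting, with a stated time of 2 days (a lower number here means a stronger inhibitor, a higher number a weaker inhibitor), compound 1 gives 1100 nM, the lowest of the three numbers measured. Compound 3 `COc1cccc(Cc2nn3cc(-c4cccc(N)c4)nc3s2)c1` gives 10000 nM, and compound 2 `COc1ccc(-c2nn3cc(-c4cccc(N)c4)nc3s2)cc1OC` gives 13000 nM; those two values lie within the scatter of each other, although their substituents on the shared core are not the same. Going by the values given here, the one step that is measured, a 9.1-fold higher number from compound 1 to compound 3 (0.96 log units; beyond the scatter), concerns a different position from the one that changes here, so it offers no direct guide.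

Compound 4 `C=C(Br)C(=O)Nc1cccc(-c2cn3nc(-c4cccs4)sc3n2)c1` carries thiophen-2-yl in place of 3-methoxybenzyl on an aromatic carbon. Among the compounds with values here, no measured pair shows exactly this exchange. What the values of compound 2 and compound 3 do show is that two different groups at this same position leave this assay's read-out nearly unchanged, which argues for a small effect rather than a large one. Compound 4 is therefore expected to show a 1.4-fold higher number from compound 1 to compound 4 (0.13 log units; within the scatter), a step that may well stay within the scatter. The estimate for compound 4 in this assay is 1500 nM, with a plausible range from 400 nM to 6000 nM.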

Compound 4, half-maximal inhibitory concentration: 370 nM
Estimate against measurement, compound 4: 4.1-fold (0.61 log units) above; the whole stated range lies above it.
By their numbers in this assay, from the lowest: compound 4; then compound 1; then compounds 3 and 2 (each within the scatter of the next).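

In this assay, thiophen-2-yl in place of 3-methoxybenzyl gives a 3.0-fold lower number from compound 1 to compound 4 (0.47 log units; beyond the scatter), so with the (1-bromoethenyl)carbonyl present, a change at this position moves the read-out beyond the scatter. Compound 2 and compound 3 had differed at this same position while staying within the scatter of each other, but both carry hydrogen in place of the (1-bromoethenyl)carbonyl on that nitrogen, so the small difference between them does not carry over to compound 1 and compound 4. No evidence is at hand on what lies behind the lower number of compound 4.

The compounds shown leave open whether the lower number belongs to thiophen-2-yl itself or would also come with another group at this position, such as furan-2-yl, phenyl or a plain methyl. They also leave open whether thiophen-2-yl would give a step of this kind on a compound that carries hydrogen on that nitrogen in place of the (1-bromoethenyl)carbonyl.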